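The source may report more compounds than this note shows. Statements on the series, on what has been measured and on what is new or still open speak of the compounds shown alone.

Compound 1 `CC(CN1N=C(c2ccccc2)CCC1=O)C(=N)S` and compound 2 `N=C(S)CCCCN1N=C(c2ccccc2)CCC1=O` share one core and differ only in the chain that carries the thioamide-like end group. In a functional assay on the whole organism (stomach) for inhibition, with Rattus norvegicus as the target, at a dose of 100 mg/kg by the intraduodenal route (on this read-out higher numbers stand for more inhibition at the one dose given (going by the name of the read-out) and lower numbers for less inhibition), compound 1 gives 28.2%, and compound 2 gives 50.2%; the change between them is a number 22 percentage points higher from compound 1 to compound 2 (beyond the scatter). Going by the values given here, on these two numbers compound 2 stands highest, with compound 1 as its only neighbour, lower by that same step. Compound 3 `N=C(S)CCCCCN1N=C(c2ccccc2)CCC1=O` continues in the same direction: a group of 4 heavy atoms (2 carbon, 1 nitrogen, 1 sulfur; no ring) in place of a group of 3 heavy atoms (1 carbon, 1 nitrogen, 1 sulfur; no ring), on a saturated chain carbon, four bonds along the chain from an amide-type nitrogen in a ring. Among the compounds with values here, the one measured step that bears on this is the lengthening from compound 1 to compound 2, which raised inhibition modestly, so a further rise is expected, though only one step supports it and the next may be smaller; the expected step is a number 7.8 percentage points higher from compound 2 to compound 3 (within the scatter). For compound 3 in this assay the estimate is 58%, within a range from 35% to 80%.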

Compound 3, a percentage reported as inhibition, in the whole organism at one dose (the size of the read-out at that dose, not a potency): 48.5%
Compound 3: middle estimate off by 9.5 percentage points, on the high side; the range from low to high includes it.
By their numbers in this assay, from the lowest: compound 1; then compounds 3 and 2 (each within the scatter of the next).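

In this assay, the chain grows again and gives a number 1.7 percentage points lower from compound 2 to compound 3 (within the scatter), so compound 2 and compound 3 cannot be told apart and lengthening at this position brings no further measurable gain. Set against the shorter, branched chain, the longest group still gives a number 20.3 percentage points higher from compound 1 to compound 3 (beyond the scatter), which shows that the advantage over compound 1 survives this change. Nothing measured here explains why the read-out levels off across these two chains.

As far as these compounds go, whether a still longer chain would hold this level or lose it stays open, as does what a carboxylic acid or an amine would do in place of the end group. From the compounds shown here alone, with only one dose, it also remains unknown whether compound 2 and compound 3 would stay together at other doses.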